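The source may hold more compounds than are shown below. What is called first, only, known or untested is meant among the compounds shown, and "the series" means these compounds.

For the measured compounds named here, compound 2 `CCCCCCCC#CC#CCO` gives 5.48 ug/mL in a functional assay on A549 cells (Homo sapiens) for cytotoxicity (on this read-out higher numbers stand for an effect only at larger amounts of compound and lower numbers for an effect already at smaller amounts), the second highest of the three numbers known. Compound 3 `CCCCCCCC#CC#CC(O)CC(C)=O` gives 4.17 ug/mL, and compound 1 `C=CCCCCCC#CC#CCO` gives 13.8 ug/mL. The step of a 2.5-fold lower number from compound 1 to compound 2 (0.40 log units; beyond the scatter) concerns the far end of the chain and has little to say about the hydroxy end. The step of a 1.3-fold lower number from compound 2 to compound 3 (0.12 log units; within the scatter) alters the carbon carrying the hydroxy and is the only one that bears on the present change. Compound 4 `CCCCCCCC#CC#CCOCC(=O)OC` differs from compound 2 in that ((methoxycarbonyl)methyl in place of hydrogen on an oxygen on a saturated carbon). Going by the values given here, with the one related step staying within the scatter, no step beyond the scatter is expected here. The expected step is a 1.0-fold higher number from compound 2 to compound 4 (0.00 log units; within the scatter). Compound 4 is therefore estimated at 5.5 ug/mL, with a range from 2.2 ug/mL to 14 ug/mL.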

Compound 4, concentration for half-maximal effect: > 30 ug/mL
Compound 4 ended at the assay's limit; the forecaster's own chance of this, stated with the estimate: 5%; at least 5.4-fold (0.73 log units) between middle value and limit.
By their numbers in this assay, from the lowest: compounds 3 and 2 (each within the scatter of the next); then compound 1. At a limit, above all of these: compound 4.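

Putting (methoxycarbonyl)methyl in place of hydrogen on this oxygen brings an at least 5.4-fold higher number from compound 2 to compound 4 (0.73 log units; beyond the scatter) in this assay, whereas compound 3, which keeps that hydrogen and changes the carbon carrying the hydroxy, stays within the scatter of compound 2. So the hydroxy oxygen is the first place in this series where a change at the hydroxy end shows a clear effect. The reading for compound 4 is a limit of the assay, not a number: (the limit of > 30 ug/mL in this assay, at which 1 of the 4 values shown sits).

From the compounds shown here alone, it remains open whether any group on this oxygen would do the same or whether the methyl ester matters. A simple methyl ether or the corresponding carboxylic acid on the same oxygen would tell these apart.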